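The compounds below may be only part of what the source reports. "The series", "measured", "known", "first", "only" and "open" are said of these compounds alone.

Measured so far in a physicochemical assay for lipophilicity, at pH 7.4; on this read-out higher numbers stand for higher lipophilicity and lower numbers for lower lipophilicity:

- compound 1, `CCc1ccc(N(CC(C)C)S(=O)(=O)c2ccc3c(c2)C(=O)CC(c2c(C)noc2C)O3)cc1`, gives 4.42
- compound 2, `CCc1ccc(N(CC(C)C)S(=O)(=O)c2ccc3c(c2)C(=O)CC(C2CCNCC2)O3)cc1`, gives 2.21

Among the compounds with values here, compound 2 stands lowest of the two numbers in this assay, and the only measured neighbour is compound 1, which sits well higher: a number 2.21 log units lower from compound 1 to compound 2 (beyond the scatter). That step exchanged one group for another on a saturated ring carbon of the shared core.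

Compound 3, `CCc1ccc(N(CC(C)C)S(=O)(=O)c2ccc3c(c2)C(=O)CC(C2CCN(S(=O)(=O)C4CCCC4)CC2)O3)cc1`, is the next compound to be measured in this assay. It differs from compound 2 in one place: cyclopentylsulfonyl in place of hydrogen on an amine nitrogen in a ring. Within the data shown here, no measured step covers a change of this kind on the amine nitrogen in a ring, so the step from compound 1 to compound 2 bears on it only loosely, in showing that a single exchange at this end of the shared core can move the read-out by a large amount. A large step upward is therefore expected here, a number 1.99 log units higher from compound 2 to compound 3 (beyond the scatter), so that compound 3 lands in the region of compound 1. The estimate for compound 3 in this assay is 4.2, with a range from 3.5 to 4.9.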

Compound 3, distribution coefficient: 4.75
Compound 3: middle estimate off by 0.55 log units, on the low side; low and high end bracket the measured number.
By their numbers in this assay, from the lowest: compound 2; then compound 1; then compound 3.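

In this assay, cyclopentylsulfonyl in place of hydrogen on the amine nitrogen in the ring gives a number 2.54 log units higher from compound 2 to compound 3 (beyond the scatter) and so moves the number upward by a large amount. Within the data shown here, the earlier step, a number 2.21 log units lower from compound 1 to compound 2 (beyond the scatter), was an exchange on a saturated ring carbon, whereas this result is the first to show that a change on the nitrogen itself, three ring bonds from the ring atom that bears a large group, can also shift the read-out strongly while the rest of compound 2 stays the same. The entering group adds 8 heavy atoms and 2 hydrogen-bond acceptors with no net charge, but no measurement on hand explains why the number rises by this much.

The compounds shown leave open whether this rise needs the five-membered carbon ring, the sulfonyl link or simply any substituent on that nitrogen, as cyclopentylsulfonyl is the only group seen there. Methylsulfonyl, acetyl or a plain methyl on the same nitrogen would help separate these parts of the change.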